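Changing the aryl group on the amide carbonyl

This account rests on a few compounds, and the source may have more. Where it says the series, first, only, none or still open, it means among the compounds named here.

Compound 1 `O=C(/C=C/c1cccc(NC(=O)c2ccccc2Cl)c1)c1nc2ccccc2[nH]1`: 1280 nM
Compound 2 `O=C(Nc1cccc(/C=C/C(=O)c2nc3ccccc3[nH]2)c1)c1ccc(Br)cc1`: 2230 nM
Compound 3 `COc1cccc(C(=O)Nc2cccc(/C=C/C(=O)c3nc4ccccc4[nH]3)c2)c1`: 3680 nM

The three measured compounds share one core and differ only in the aryl group attached to the amide carbonyl carbon. In a functional assay on HCT-116 cells (Homo sapiens) for antiproliferative activity, read by MTT assay, with a stated time of 48 h (a higher number here means a weaker inhibitor, a lower number a stronger inhibitor), compound 1 gives the lowest of the three numbers. Its nearest neighbour is compound 2, with a 1.7-fold higher number from compound 1 to compound 2 (0.24 log units; within the scatter), a gap within the scatter; its furthest is compound 3, with a 2.9-fold higher number from compound 1 to compound 3 (0.46 log units; beyond the scatter), a modest but real gap.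

Compound 4 `COc1ccc(C(=O)Nc2cccc(/C=C/C(=O)c3nc4ccccc4[nH]3)c2)cc1` has not yet been measured. It differs from compound 1 in one place: 4-methoxyphenyl in place of 2-chlorophenyl on a carbonyl carbon.

Among the measured compounds shown here, two measured steps bear on this change. Replacing the 2-chlorophenyl group with a 4-bromophenyl group moved the number little, and replacing it with a 3-methoxyphenyl group raised it modestly. Both changes away from the 2-chlorophenyl group gave a higher number, so a higher number is expected for compound 4 as well, most likely small to modest in size.

For compound 4 the expected step is a 2.0-fold higher number from compound 1 to compound 4 (0.29 log units; within the scatter), giving an estimate of 2500 nM, with a likely range from 1000 nM to 6000 nM.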

Compound 4, half-maximal inhibitory concentration: 4880 nM
Compound 4: middle estimate off by 2.0-fold (0.29 log units), on the low side, and the stated range covers the measured number.
By their numbers in this assay, from the lowest: compounds 1, 2, 3 and 4 (each within the scatter of the next, the first and the last beyond it).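

In this assay the 4-methoxyphenyl group is a third replacement for the 2-chlorophenyl group on the amide carbonyl, and it too gives a higher number (a 3.8-fold higher number from compound 1 to compound 4 (0.58 log units; beyond the scatter)), so a second group now shows a step from compound 1 that lies beyond the scatter. Moving the methoxy group on the ring gives no readable change between the 3-methoxyphenyl and 4-methoxyphenyl groups (a 1.3-fold higher number from compound 3 to compound 4 (0.12 log units; within the scatter)), so these two compounds do not show that the methoxy group's place on the ring matters in this assay. The new compound also gives the first readable difference between a bromo and a methoxy group on the ring (a 2.2-fold higher number from compound 2 to compound 4 (0.34 log units; beyond the scatter)), whereas the step from compound 2 to the 3-methoxyphenyl compound 3 stayed within the scatter.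

The data shown offer no measurement that explains why these aryl groups give different numbers. Also open, going by these compounds, is how an unsubstituted phenyl ring, or a ring carrying an amine or a carboxylic acid, would compare with the 2-chlorophenyl group of compound 1 at this position.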